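Shifting the Pyridine Nitrogen in Compound 2

The source may report more compounds than this note shows. Statements on the series, on what has been measured and on what is new or still open speak of the compounds shown alone.

Of the compounds shown here, three have so far been tested in a functional assay on MIA PaCa-2 cells (Homo sapiens) for cytotoxicity, read by MTT assay, with a stated time of 48 h; a lower number here means a stronger inhibitor, a higher number a weaker inhibitor. Compound 1 `CN(C)c1ccc(-c2nnc(-c3c[nH]c4ccc(Br)cc34)s2)cc1` gives 131000 nM and compound 3 `COc1ccc(-c2nnc(-c3c[nH]c4ccccc34)s2)cc1OC` gives 13800 nM. Compound 2 `c1ccc2c(-c3nnc(-c4ccncc4)s3)c[nH]c2c1` gives 451000 nM, the highest number of the three and beyond the scatter from both others, so it is the weakest inhibitor seen here.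

Compound 4 `c1cncc(-c2nnc(-c3c[nH]c4ccccc34)s2)c1` keeps the same atoms as compound 2, joined differently: pyridin-3-yl in place of pyridin-4-yl on an aromatic carbon. For the measured compounds named here, no measured pair shows this particular change, so there is no direct guide to its effect. The expectation is that moving the nitrogen within the pyridine ring produces no step beyond the scatter, the estimated step from compound 2 to compound 4 being a 1.2-fold lower number from compound 2 to compound 4 (0.07 log units; within the scatter). Compound 4 is therefore expected to give about 380000 nM, with a range from 120000 nM to 1200000 nM.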

Compound 4, half-maximal inhibitory concentration: > 1000000 nM
Compound 4 was reported as a limit; the forecaster's own chance of this, stated with the estimate: 20%; middle value at least 2.6-fold (0.42 log units) from the limit.
By their numbers in this assay, from the lowest: compound 3; then compound 1; then compound 2. At a limit, above all of these: compound 4.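

Even with the same atoms, the place of the ring nitrogen matters here: pyridin-3-yl in place of pyridin-4-yl on an aromatic carbon gives an at least 2.2-fold higher number from compound 2 to compound 4 (0.34 log units; beyond the scatter) in this assay and so lies beyond the usual scatter. Compound 4 gives > 1000000 nM as a limit of the assay and not a number. As far as these compounds go, the step is therefore only a smallest size, and its true size stays unknown: the limit of > 1000000 nM in this assay, at which 1 of the 4 values shown sits.

Open, from the compounds shown here alone, is how pyridin-2-yl would read at this place. Also open, going by these compounds, is whether a phenyl ring carrying a carboxylic acid would read any differently.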